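Hydroxy-bearing ring replaces ethyl on the amino nitrogen

A few compounds are considered here, and "the series" means these few. Any claim that something is new, unique, unknown or untested is made for them only; others in the source may bear on it.

Compound 1 `COc1ccc(C(=O)Nc2nc(-c3ccccc3)nc3c2nnn3Cc2ccccc2F)cc1` gives 21900000 nM in an assay on isolated protein for binding affinity to adenosine receptor A1 (Bos taurus); a higher number here means a weaker inhibitor, a lower number a stronger inhibitor.
Compound 2 `OCCCNc1nc(-c2ccccc2)nc2c1nnn2Cc1ccccc1F` gives 3700000 nM in this assay.
Compound 3 `CCNc1nc(-c2ccccc2)nc2c1nnn2Cc1ccccc1F` gives 11000000 nM in this assay.

Compound 3 stands second highest of the three numbers: the step of a 2.0-fold lower number from compound 1 to compound 3 (0.30 log units; within the scatter) lies within the scatter, whereas a 3.0-fold higher number from compound 2 to compound 3 (0.47 log units; beyond the scatter) lies beyond it. Compound 4 `OC1CCC(Nc2nc(-c3ccccc3)nc3c2nnn3Cc2ccccc2F)CC1` has not been measured. The change is 4-hydroxycyclohexyl in place of ethyl on a nitrogen on an aromatic ring. The step that bears on it most directly is a 3.0-fold higher number from compound 2 to compound 3 (0.47 log units; beyond the scatter), read in reverse, where a hydroxyl-bearing group entering on the chain lowered the number modestly; a 5.9-fold lower number from compound 1 to compound 2 (0.77 log units; beyond the scatter) points the same way. A modest lowering is therefore expected, a 2.8-fold lower number from compound 3 to compound 4 (0.44 log units; beyond the scatter), in this assay. Compound 4 is estimated at 4000000 nM, with a range from 1500000 nM to 12000000 nM.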

Compound 4, inhibition constant: 1850000 nM
Compound 4: middle estimate off by 2.2-fold (0.33 log units), on the high side; the range from low to high includes it.
By their numbers in this assay, from the lowest: compounds 4 and 2 (each within the scatter of the next); then compounds 3 and 1 (each within the scatter of the next).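

Replacing ethyl with 4-hydroxycyclohexyl on the nitrogen gives a 5.9-fold lower number from compound 3 to compound 4 (0.77 log units; beyond the scatter) in this assay and shows that a six-membered ring carrying a hydroxyl can stand at this position as well as a chain. The ring and the 3-hydroxypropyl chain differ by a 2.0-fold lower number from compound 2 to compound 4 (0.30 log units; within the scatter) and so cannot be told apart here. Against (4-methoxyphenyl)carbonyl, the ring gives a 12-fold lower number from compound 1 to compound 4 (1.07 log units; beyond the scatter) as the largest step in the set. Nothing available explains these steps. Going by these compounds, it remains open whether plain cyclohexyl or 4-aminocyclohexyl would give a similar number.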